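Methyl on the phenyl ring across two cores

The compounds below may be only part of what the source reports. "The series", "measured", "known", "first", "only" and "open" are said of these compounds alone.

Measured so far in an assay on isolated protein for inhibition of Amine oxidase [flavin-containing] B (Homo sapiens), read by fluorescence and spectrophotometry, with a stated time of 20 min; a higher number here means a weaker inhibitor, a lower number a stronger inhibitor:
Compound 1 `COn1c(-c2ccccc2)c(C=O)c2cc(C#N)c(C#N)cc21`: the value is a limit of the assay, > 100000 nM.
Compound 2 `COn1c(-c2ccc(C)cc2)c(C=O)c2cc(C#N)c(C#N)cc21`: 74800 nM.
Compound 3 `O=C(O)c1cc2cc(-c3ccccc3)n(O)c2cc1C(=O)O`: 56200 nM.

Compound 1 and compound 2 share one core and differ in a single place, (methyl in place of hydrogen on an aromatic carbon). The step is an at least 1.3-fold lower number from compound 1 to compound 2 (0.12 log units; that floor lies within the scatter); it can only be stated as a floor because compound 1 sits at the limit of > 100000 nM in this assay, at which 1 of the 3 values shown sits, so the true size of the change on this core is not known.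

Compound 3 carries a different core; the difference between the two cores is not broken down here. In this assay compound 3 and compound 2 lie within the usual scatter of each other, so no order between them is drawn.

Compound 4 `Cc1ccc(-c2cc3cc(C(=O)O)c(C(=O)O)cc3n2O)cc1` is not yet measured. It differs from compound 3 as methyl in place of hydrogen on an aromatic carbon, and the place of the change is described in the same words as for the pair compound 1 to compound 2, so it is treated as the same change made on the second core. For this assay a step of a 1.4-fold lower number from compound 3 to compound 4 (0.15 log units; within the scatter) is expected, placed beside the earlier one and resting on the bounded and small step an at least 1.3-fold lower number from compound 1 to compound 2 (0.12 log units; that floor lies within the scatter). As the starting point compound 3 gives 56200 nM in this assay. Compound 4 is therefore estimated at 40000 nM in this assay, with a likely range from 15000 nM to 100000 nM.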

Compound 4, half-maximal inhibitory concentration: > 100000 nM
Compound 4: a limit, no number; the forecaster's own chance of this, stated with the estimate: 20%; middle value at least 2.5-fold (0.39 log units) from the limit.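

In this assay compound 4 gives > 100000 nM, which is a limit of the assay and not a number. On the second core, the change from phenyl to 4-methylphenyl gives an at least 1.7-fold higher number from compound 3 to compound 4 (0.25 log units; that floor lies within the scatter), and the comparison with the first core stays unresolved: the same change on two cores in this assay, an at least 1.3-fold lower number (0.12 log units; that floor lies within the scatter) from compound 1 to compound 2 and an at least 1.7-fold higher number (0.25 log units; that floor lies within the scatter) from compound 3 to compound 4; the limit leaves it open whether they differ. This does not show that the methyl step carries from one core to the other, nor that it fails to carry, since neither step has a known size and both are known only as floors set by the same assay limit: the limit of > 100000 nM in this assay, at which 2 of the 4 values shown sit.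

On these data alone, the true size of the methyl step on each core remains open, as does whether the two cores respond to this change alike. Also open, as far as these compounds go, is whether another group in the same place on the phenyl ring, such as chlorine or an ethyl chain, would give readable values on both cores and so allow a direct comparison of the steps.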